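The compounds below may be only part of what the source reports. "The series", "measured", "known", "first", "only" and "open" are said of these compounds alone.

Measured compounds:
Compound 1 `COc1c(OCCCN2CCN(C)CC2)cc(O)c2c(=O)cc(-c3ccccc3)oc12` gives 9900 nM in a functional assay on A549 cells (Homo sapiens) for cytotoxicity, read by MTT assay, with a stated time of 48 h; a lower number here means a stronger inhibitor, a higher number a weaker inhibitor.
Compound 2 `O=c1cc(-c2ccccc2)oc2c(OCCNCCO)c(O)cc(O)c12` gives "not determined" (no result reported) in this assay.
Compound 3 `CNCCOc1c(O)cc(O)c2c(=O)cc(-c3ccccc3)oc12` gives "not determined" (no result reported) in this assay.

Among these three, compound 1 is the only one for which a number is known in this assay. For the measured compounds named here, for compound 2 and compound 3 no result was reported, so no step between measured compounds can be read, and the data give no indication of how a change at the end of the chain moves the read-out. Compound 1 itself sits at a weak level in this assay.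

Compound 4 `COc1c(OCCCCN2CCCCC2)cc(O)c2c(=O)cc(-c3ccccc3)oc12` has yet to be measured. It differs from compound 1 in a single place: (piperidin-1-yl)methyl in place of 4-methylpiperazin-1-yl on a saturated chain carbon, three bonds along the chain from an oxygen on an aromatic ring. The shared core and the phenyl group are untouched; only the group at the far end of the chain and the length of that chain are changed.

Going by the values given here, with no measured step to lean on, the expectation for this assay is a step of about a 1.2-fold lower number from compound 1 to compound 4 (0.09 log units; within the scatter), which is essentially none beyond the usual scatter, in no firm direction. The estimate rests on compound 1 and its 9900 nM alone. Compound 4 is therefore expected to give about 8000 nM in this assay, with a range from 2500 nM to 25000 nM.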

Compound 4, half-maximal inhibitory concentration: 1150 nM
Estimate against measurement, compound 4: 7.0-fold (0.84 log units) above; measured number outside the range, below it.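

In this assay, for the compounds shown here, replacing the 3-(4-methylpiperazin-1-yl)propyl group of compound 1 with the 4-(piperidin-1-yl)butyl group of compound 4 gives an 8.6-fold lower number from compound 1 to compound 4 (0.93 log units; beyond the scatter) and so provides the first readable step in this set, as the steps involving compound 2 and compound 3 cannot be read. It shows that the read-out is sensitive to a change at the far end of the chain on the shared core, with the change here moving it towards a stronger inhibitor by more than the usual scatter. No measurement shown here accounts for this step.

The chain length and the ring at its end change together between compound 1 and compound 4, so the step cannot be divided between them; a piperidine on the propyl chain or a 4-methylpiperazine on the butyl chain would be needed to separate the two. From the compounds shown here alone, how far the trend extends also remains open, whether towards a still longer chain such as pentyl or towards another ring such as morpholine at the chain end.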